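A few compounds are considered here, and "the series" means these few. Any claim that something is new, unique, unknown or untested is made for them only; others in the source may bear on it.

In a physicochemical assay for solubility, using the shake flask method, in simulated intestinal fluid, measured as kinetic solubility, with a stated time of 2 h, at 25 degrees C, at pH 6.5 (on this read-out lower numbers stand for lower solubility and higher numbers for higher solubility), compound 2 (`Cc1noc(-c2nc(C)c3c(c2N)C(=O)N(CC2CCNCC2)C3=O)n1`) gives 160000 nM and compound 3 (`Cc1noc(-c2nc(C)c3c(c2N)C(=O)N(CC2CCOCC2)C3=O)n1`) gives 5700 nM, the lower of the two numbers. The step of a 28-fold lower number from compound 2 to compound 3 (1.45 log units; beyond the scatter) is large and shows how far a swap at this place can move the read-out. Compound 1 (`Cc1noc(-c2nc(C)c3c(c2N)C(=O)N(Cc2ccc(-n4cccn4)cc2)C3=O)n1`) carries an aromatic ring at the same place, and this assay gives only a limit for it, < 5000 nM. Compound 4 (`Cc1noc(-c2nc(C)c3c(c2N)C(=O)N(Cc2ccc(Cl)cc2)C3=O)n1`) has not yet been measured. It has 4-chlorophenyl in place of oxan-4-yl on a saturated chain carbon bound to an amide-type nitrogen in a ring. Among the measured compounds shown here, no measured step makes this exact change, so the limit for compound 1 is the closest guide, and the large step from the other swap is a warning rather than a measure. A small fall is therefore expected in this assay, not a rise. The expected step is a 1.9-fold lower number from compound 3 to compound 4 (0.28 log units; within the scatter). For compound 4 the estimated value is 3000 nM, with an expected range from 800 nM to 7000 nM.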

Compound 4, solubility: < 5000 nM
Compound 4 ended at the assay's limit (the forecaster's own chance of this, stated with the estimate: 70%); the middle value is on the limit's open side.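

In this assay, 4-chlorophenyl on this saturated chain carbon puts a second compound with an aromatic ring at the limit, alongside compound 1: the limit of < 5000 nM in this assay, at which 2 of the 4 values shown sit. The swap from oxan-4-yl gives an at least 1.1-fold lower number from compound 3 to compound 4 (0.05 log units; that floor lies within the scatter), so the size of this change stays hidden, whereas the swap from piperidin-4-yl gives an at least 32-fold lower number from compound 2 to compound 4 (1.50 log units; beyond the scatter), which sets compound 2 well apart. The step between compound 1 and compound 4 cannot be read, as both values are limits.

The compounds shown leave open how far compound 4 lies past the limit. They also leave open whether an amine in place of the chloro on the aromatic carbon would bring the number back into the measurable range.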